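Trifluoromethyl for fluoro on the pendant phenyl ring

This account rests on a few compounds, and the source may have more. Where it says the series, first, only, none or still open, it means among the compounds named here.

Measured so far:
compound 2 `Cc1ccc(-c2cc(CCC(=O)N3CCN(Cc4ccc(C(C)(C)C)cc4)CC3)nn2-c2ccc(Cl)cc2)cc1` — 2900 nM
compound 3 `CC(C)(C)c1ccc(CN2CCN(C(=O)CCc3cc(-c4ccc(F)cc4)n(-c4ccc(Cl)cc4)n3)CC2)cc1` — 2600 nM
compound 1 `O=C(CCc1cc(-c2ccc(C(F)(F)F)cc2)n(-c2ccc(Cl)nn2)n1)N1CCN(C(=O)c2ccco2)CC1` — "not determined" (no result reported) in an assay on isolated protein for inhibition of Polyunsaturated fatty acid 5-lipoxygenase (Homo sapiens), read by HPLC, with a stated time of 15 min, in the presence of a further agent that is not named here; on this read-out higher numbers stand for weaker inhibition and lower numbers for stronger inhibition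

Compound 3 and compound 2 lie within the scatter of each other: a 1.1-fold lower number from compound 2 to compound 3 (0.05 log units; within the scatter). Compound 1 has no number in this assay and gives no anchor for a trifluoromethyl group in this position.

Compound 4 `CC(C)(C)c1ccc(CN2CCN(C(=O)CCc3cc(-c4ccc(C(F)(F)F)cc4)n(-c4ccc(Cl)cc4)n3)CC2)cc1` differs from compound 3 in one place: trifluoromethyl in place of fluoro on an aromatic carbon. Among the compounds with values here, no measured step covers this change. Within the data shown here, the only step, from compound 2 to compound 3, swapped methyl for fluoro at the same position and stayed within the scatter. By analogy, the step from compound 3 to compound 4 is expected to be small as well, in no fixed direction, giving a 1.0-fold lower number from compound 3 to compound 4 (0.02 log units; within the scatter). For compound 4 the estimated value in this assay is 2500 nM, with a range of 900 nM to 7000 nM; the range is wide because the change is not covered by any measured step.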

Compound 4, half-maximal inhibitory concentration: 8000 nM
The estimate for compound 4 lay 3.2-fold (0.51 log units) below the measured number, outside the stated range (above it).
By their numbers in this assay, from the lowest: compounds 3 and 2 (each within the scatter of the next); then compound 4.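

In this assay this position proves not to be indifferent to its substituent: trifluoromethyl in place of fluoro gives a 3.1-fold higher number from compound 3 to compound 4 (0.49 log units; beyond the scatter), and trifluoromethyl in place of methyl gives a 2.8-fold higher number from compound 2 to compound 4 (0.44 log units; beyond the scatter). Both steps are modest, yet both lie beyond the scatter, whereas the exchange of methyl and fluoro gave only a 1.1-fold lower number from compound 2 to compound 3 (0.05 log units; within the scatter), so among these three groups only trifluoromethyl separates from the others. No available measurement accounts for this shift.

On these data alone, how a methoxy group, a nitrile or an amine would behave at this position stays open. As far as these compounds go, compound 1 also carries trifluoromethyl but has no number in this assay, so whether the step holds with a different remainder of the molecule also stays open.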